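The source may hold more compounds than are shown below. What is called first, only, known or untested is meant among the compounds shown, and "the series" means these compounds.

Of the compounds shown here, two that share one core have been tested in an ADME assay on HepG2 cells (Homo sapiens) for inhibition, with a stated time of 48 h; a lower number here means that less compound is needed, a higher number that more compound is needed for the effect. Compound 1 is `C[C@@H](C(=O)N1CCCCC1)N1CCN(S(=O)(=O)c2ccc(C(C)(C)C)cc2)CC1`. In this assay compound 1 gives only a limit, > 40000 nM. Compound 2 is `CC(C(=O)N1CCCCCC1)N1CCN(S(=O)(=O)c2ccc(C(C)(C)C)cc2)CC1`. In this assay compound 2 also gives only a limit, > 40000 nM. Both values sit at the limit of > 40000 nM in this assay, at which 2 of the 2 values shown sit, so compound 2 stands where compound 1 stands, at the edge of what the assay reports. Compound 3, `CC(C(=O)N(C)Cc1ccccc1)N1CCN(S(=O)(=O)c2ccc(C(C)(C)C)cc2)CC1`, has not yet been measured. It differs from compound 2 in one place: benzyl(methyl)amino in place of azepan-1-yl on a carbonyl carbon. For the measured compounds named here, no measured pair of compounds shows what this kind of change does here, and the two values that exist are limits, so no direction can be read from them. The expected step from compound 2 to compound 3 is a number no higher from compound 2 to compound 3 (the limit leaves the size open), that is, none beyond the scatter. For compound 3 the estimate in this assay is 40000 nM, with a likely range from 15000 nM to 120000 nM, and it will most probably again be reported only as a limit.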

Compound 3, half-maximal effective concentration: > 40000 nM
Compound 3 gave a limit, no number; the forecaster's own chance of this, stated with the estimate: 85%; the middle value lies on the limit itself.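

In this assay compound 2 and compound 3 both give only a limit, so no step can be read between them: the limit of > 40000 nM in this assay, at which 3 of the 3 values shown sit. The compounds shown leave open what concentration, if any, would reach the half-maximal effect on these cells.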